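The compounds below may be only part of what the source reports. "The series", "measured", "known", "first", "only" and "open" are said of these compounds alone.

Measured compounds:
- compound 1, `CN(C)CCNc1nc(NCc2ccco2)c2ccccc2n1`: "not determined" (no result reported)
- compound 2, `Cc1cccc(N2CCN(CCCCNc3nc(NCc4ccco4)c4cc(F)ccc4n3)CC2)c1C`: 97.4%
- compound 3, `Fc1ccc2nc(NCCN3CCN(c4cccc(Cl)c4Cl)CC3)nc(NCc3ccco3)c2c1`: "not determined" (no result reported)

The account follows the step from compound 1 to compound 4, `CCN(CC)CCNc1nc(NCc2ccco2)c2ccccc2n1`. In a functional assay on HCT-116 cells (Homo sapiens) for cytotoxicity, read by MTT assay, with a stated time of 2 days, tested at 10 uM (a lower number here means less inhibition, a higher number more inhibition at the concentration tested (going by the name of the read-out)), compound 1 stands without a single number, its result being "not determined" (no result reported), and compound 3 likewise reports "not determined" (no result reported). Only compound 2 gives a number in this assay, 97.4%, on a core that differs from compound 1 in more than one place. The change to compound 4 is diethylamino in place of dimethylamino on a saturated chain carbon, two bonds along the chain from a nitrogen on an aromatic ring. Among the measured compounds shown here, with no measured pair showing this step, no direction in this assay can be drawn from the data; the step is expected to lie within the scatter, if anywhere. Compound 4 is estimated at 40%, in the range 5% to 90%.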

Compound 4, a percentage reported as inhibition, at one concentration (the size of the read-out at that concentration, not a potency): 50.3%
Estimate against measurement, compound 4: 10.3 percentage points below; measured number inside the range.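

In this assay, among the compounds shown here, compound 4 gives 50.3% and compound 1 gives "not determined" (no result reported), so no step between them can be read, and no supporting evidence bears on the result. The compounds shown leave open how diethylamino compares with dimethylamino on this shared core.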